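Adding a second trifluoromethyl group to compound 1

A few compounds are considered here, and "the series" means these few. Any claim that something is new, unique, unknown or untested is made for them only; others in the source may bear on it.

In a functional assay on CWR22R cells (Homo sapiens) for antiproliferative activity, read by propidium iodide staining, with a stated time of 96 h (on this read-out lower numbers stand for stronger inhibition and higher numbers for weaker inhibition), compound 1 (`CC(O)(CS(=O)(=O)c1cccc(C(F)(F)F)c1)C(=O)Nc1ccc(S(F)(F)(F)(F)F)cc1`) gives 23800 nM and compound 2 (`CC(O)(CS(=O)(=O)c1ccccc1C(F)(F)F)C(=O)Nc1ccc(S(F)(F)(F)(F)F)cc1`) gives 17400 nM so the two stand within the scatter of each other. Compound 3 (`CC(O)(CS(=O)(=O)c1cc(C(F)(F)F)cc(C(F)(F)F)c1)C(=O)Nc1ccc(S(F)(F)(F)(F)F)cc1`) has trifluoromethyl in place of hydrogen on an aromatic carbon of compound 1 (trifluoromethyl in place of hydrogen on an aromatic carbon). Going by the values given here, the one measured step that bears on this is a 1.4-fold lower number from compound 1 to compound 2 (0.14 log units; within the scatter) for 2-(trifluoromethyl)phenyl in place of 3-(trifluoromethyl)phenyl on a sulfonyl sulfur. That step relocates the group rather than adding one, so it is only a loose guide. Expected in this assay is a 1.2-fold lower number from compound 1 to compound 3 (0.08 log units; within the scatter) and nothing beyond the scatter. Compound 3 is estimated at 20000 nM (expected range 8000 nM to 50000 nM).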

Compound 3, half-maximal inhibitory concentration: 12700 nM
Compound 3: the middle estimate sits 1.6-fold (0.20 log units) above what was measured; low and high end bracket the measured number.
By their numbers in this assay, from the lowest: compounds 3, 2 and 1 (each within the scatter of the next).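

In this assay, trifluoromethyl in place of hydrogen on this aromatic carbon, meta to a trifluoromethyl group, gives a 1.9-fold lower number from compound 1 to compound 3 (0.27 log units; within the scatter). Where the earlier step only moved the group, this one adds a second trifluoromethyl group, and the position accepts it with no change beyond the scatter. Nothing at hand accounts for this result.

As far as these compounds go, whether an amine or a nitrile on the same aromatic carbon would move the number beyond the scatter stays open.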